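Series notes: phenylsulfanyl for hydroxy on the pendant ring

This account rests on a few compounds, and the source may have more. Where it says the series, first, only, none or still open, it means among the compounds named here.

Compound 3 `COc1cc(OCc2cccc(O)c2)c2cc(-c3cn4nc(OC)sc4n3)oc2c1` gives 2700 nM in an assay on a cell-free system (plasma) for antagonist activity at proteinase-activated receptor 4 (Homo sapiens), with a stated time of 5 min, in the presence of a further agent that is not named here; on this read-out lower numbers stand for stronger inhibition and higher numbers for weaker inhibition. On the numbers shown it stands lowest of two, with compound 2 `COc1nn2cc(-c3cc4ccccc4o3)nc2s1`, at 15000 nM in this assay, the nearest. Compound 1 `COc1cc(OCc2ccccc2OC)c2cc(-c3cn4nc(OC)sc4n3)oc2c1` sits at the limit of > 1000 nM in this assay, a limit and not a number. The step from compound 1 to compound 3 therefore cannot be read: a step that the limit leaves unreadable from compound 1 to compound 3, owing to the limit of > 1000 nM in this assay, at which 1 of the 3 values shown sits.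

Compound 4 `COc1cc(OCc2cccc(Sc3ccccc3)c2)c2cc(-c3cn4nc(OC)sc4n3)oc2c1` is not yet measured. It differs from compound 3 in one place: phenylsulfanyl in place of hydroxy on an aromatic carbon. Among the measured steps, only the one from compound 1 to compound 3 touches the same aromatic ring, and its size is unreadable, so no measured step gives a direction or a size for the present change. Among the compounds with values here, compound 2, which lacks the whole substituted arm, sits higher than compound 3, but no step between those two is computed, and their values show only that the arm is present in the lower number.

With no readable precedent, the expected step from compound 3 to compound 4 is a 1.4-fold lower number from compound 3 to compound 4 (0.13 log units; within the scatter), held close to none beyond the scatter. Compound 4 is thus expected near 2000 nM in this assay, between 400 nM and 10000 nM.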

Compound 4, half-maximal inhibitory concentration: 410 nM
The estimate for compound 4 lay 4.9-fold (0.69 log units) above the measured number; measured number inside the range.
By their numbers in this assay, from the lowest: compound 4; then compound 3; then compound 2.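

In this assay, within the data shown here, phenylsulfanyl in place of hydroxy on an aromatic carbon, meta to a large group, gives a 6.6-fold lower number from compound 3 to compound 4 (0.82 log units; beyond the scatter), the first step on this pendant ring that can be read. The hydroxy and its hydrogen-bond donor can therefore leave this position, and a phenylsulfanyl carrying a six-membered aromatic ring of carbon only can enter, with a lower number rather than a higher one and a step that lies beyond the scatter. Among these compounds, the only other step on this ring cannot be read, because one value in the set is a limit and not a number: the limit of > 1000 nM in this assay, at which 1 of the 4 values shown sits.

Nothing among the values shown gives a reason for the size or direction of the step from the hydroxy compound to the phenylsulfanyl compound. As far as these compounds go, it stays open whether the sulfur link or the added aromatic ring carries the step, and a phenoxy, a benzyl or a morpholine on the same aromatic carbon, or a pyridine ring in place of the added phenyl ring, would help to separate the two.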